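Para-substituted aryl variants of the triazolopyrimidine-type core

The source may hold more compounds than are shown below. What is called first, only, known or untested is meant among the compounds shown, and "the series" means these compounds.

Compound 2 `COc1cc(-c2ccnc3cc(-c4cccc(C#N)c4)nn23)cc(OC)c1OC` carries a 3-cyanophenyl group and, in a functional assay on HCT-116 cells (Homo sapiens) for inhibition, read by CCK-8 assay, with a stated time of 48 h (a higher number here means a weaker inhibitor, a lower number a stronger inhibitor), gives only a limit, > 10000 nM, not a number. Compound 1 `COc1cc(-c2cc3nccc(-c4c[nH]c5ccccc45)n3n2)cc(OC)c1OC` likewise gives only a limit in this assay, > 10000 nM. Compound 3 `C=Cc1ccc(-c2cc3nccc(-c4cc(OC)c(OC)c(OC)c4)n3n2)cc1`, bearing 4-vinylphenyl, gives 1060 nM in this assay, so that the step of an at least 9.4-fold lower number from compound 2 to compound 3 (0.97 log units; beyond the scatter) is the one measured change with a numerical endpoint; the limit of > 10000 nM in this assay, at which 2 of the 3 values shown sit, marks where two of the three values sit, so compound 2 stands at the weak end of what is shown.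

Compound 4 `COc1ccc(-c2cc3nccc(-c4cc(OC)c(OC)c(OC)c4)n3n2)cc1` is not yet measured. It differs from compound 2 by 4-methoxyphenyl in place of 3-cyanophenyl on an aromatic carbon. Within the data shown here, the only step that bears on it is the replacement of 3-cyanophenyl by a para-substituted phenyl in an at least 9.4-fold lower number from compound 2 to compound 3 (0.97 log units; beyond the scatter), a substitution of the same kind at the same place, though with a different group. The step from compound 2 to compound 4 is therefore expected to go the same way, an at least 4.0-fold lower number from compound 2 to compound 4 (0.60 log units; beyond the scatter), with the estimate for compound 4 in this assay at 2500 nM, within 600 nM to 10000 nM.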

Compound 4, half-maximal inhibitory concentration: 404 nM
For compound 4 the middle estimate is 6.2-fold (0.79 log units) above the measured one; measured number outside the range, below it.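

In this assay, among these compounds, 4-methoxyphenyl in place of 3-cyanophenyl on this aromatic carbon gives an at least 24-fold lower number from compound 2 to compound 4 (1.39 log units; beyond the scatter), so 4-vinylphenyl is no longer the only group at this place that gives a number rather than a limit. The group carried on the phenyl ring also counts, with methoxy in place of vinyl giving a 2.6-fold lower number from compound 3 to compound 4 (0.42 log units; beyond the scatter), a step beyond the scatter. Compound 2 gives only a limit, so the step from it has no upper end and reads as a minimum: the limit of > 10000 nM in this assay, at which 2 of the 4 values shown sit.

Still open, as far as these compounds go, is whether the nitrile itself or its place on the phenyl ring separates compound 2 from compound 4, a question that 4-cyanophenyl would address. Also open, from the compounds shown here alone, is how an amine, a carboxylic acid or a longer chain such as ethoxy on that phenyl ring would compare with the methoxy of compound 4.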